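The source may report more compounds than this note shows. Statements on the series, on what has been measured and on what is new or still open speak of the compounds shown alone.

Measured so far:
compound 1, `Nc1nc(CCCc2ccccc2)nc2cn(-c3ccccc3)nc12`: 12%
compound 2, `COc1ccc(CCCc2nc(N)c3nn(-c4ccccc4)cc3n2)cc1`: 1%

In an assay on CHO cells for displacement of a labelled ligand from adenosine receptor A3 (Homo sapiens), read by scintillation counting, tested at 1 uM (a higher number here means more inhibition at the concentration tested (going by the name of the read-out), a lower number less inhibition), compound 2 gives the lowest of the two numbers. Among the compounds with values here, the nearest is compound 1, and the only measured step, a number 11 percentage points lower from compound 1 to compound 2 (beyond the scatter), lies beyond the scatter and is modest; it came with methoxy in place of hydrogen on an aromatic carbon.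

Compound 3 is `Nc1nc(CCCc2ccc(OCc3ccccc3)cc2)nc2cn(-c3ccccc3)nc12`. It differs from compound 2 by phenyl in place of hydrogen on a saturated chain carbon bound to an oxygen on an aromatic ring. Within the data shown here, no measured step covers a change of this kind; the one step known, a number 11 percentage points lower from compound 1 to compound 2 (beyond the scatter), concerns the arrival of the methoxy itself, whereas here that group is extended to benzyloxy. That step gives no direction for the present change, and both measured numbers in this assay are small. The expectation is therefore a step of a number 4 percentage points higher from compound 2 to compound 3 (within the scatter), that is, nothing beyond the scatter, with the number staying low. For compound 3 the estimate in this assay is 5%, in a range from -8% to 22%.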

Compound 3, a percentage reported as inhibition, at one concentration (the size of the read-out at that concentration, not a potency): 2%
Estimate against measurement, compound 3: 3 percentage points above; the range from low to high includes it.
By their numbers in this assay, from the lowest: compounds 2, 3 and 1 (each within the scatter of the next, the first and the last beyond it).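

In this assay, phenyl on the saturated chain carbon bound to the oxygen turns methoxy into benzyloxy and gives a number 1 percentage points higher from compound 2 to compound 3 (within the scatter), so at this position the larger group and the methoxy cannot be told apart by this read-out. Set against compound 1, benzyloxy at the aromatic carbon that bears hydrogen there gives a number 10 percentage points lower from compound 1 to compound 3 (within the scatter), whereas methoxy at the same place gives a number 11 percentage points lower from compound 1 to compound 2 (beyond the scatter); the two substituents sit on either side of the scatter limit by a narrow margin, so that contrast carries little weight, given that compound 2 and compound 3 read alike. Nothing at hand accounts for any of these numbers.

Open, going by these compounds, is whether a group of another kind at this place on the ring, such as an amine or a carboxylic acid, or a longer chain between the oxygen and the phenyl, would move the number clear of the low range seen so far. The three compounds also leave open how they would rank by potency, as the read-out comes from a single concentration and is not a potency.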